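Trifluoromethyl for methyl in compound 3

The compounds below may be only part of what the source reports. "The series", "measured", "known", "first", "only" and "open" are said of these compounds alone.

Compound 1 `Cc1ccc(-c2cc(/C=C/c3ccc(C(=O)NO)cc3)ccn2)cc1` is the only one of the three measured compounds to give a number in a functional assay on HCT-116 cells (Homo sapiens) for antiproliferative activity, read by CellTiter-Glo, with a stated time of 72 h (a higher number here means a weaker inhibitor, a lower number a stronger inhibitor), where compound 1 gives 2390 nM. The value of compound 2 `O=C(NO)c1ccc(/C=C/c2ccnc(-c3ccc(C(F)(F)F)cc3)c2)cc1` is a limit: > 10000 nM. The value of compound 3 `Cc1ccc(-c2cc(/C=C/c3ccc(C(=O)NO)cc3)c(F)cn2)cc1` is also a limit: > 10000 nM. Compound 2 and compound 3 thus stand at the limit of > 10000 nM in this assay, at which 2 of the 3 values shown sit, and compound 3 has no exact number as a starting point.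

Compound 4 `O=C(NO)c1ccc(/C=C/c2cc(-c3ccc(C(F)(F)F)cc3)ncc2F)cc1` carries trifluoromethyl in place of methyl on an aromatic carbon, para to a large group (trifluoromethyl in place of methyl on an aromatic carbon). The same replacement shows an at least 4.1-fold higher number from compound 1 to compound 2 (0.62 log units; beyond the scatter). Fluoro in place of hydrogen on an aromatic carbon shows an at least 4.1-fold higher number from compound 1 to compound 3 (0.62 log units; beyond the scatter). Both steps lie beyond the scatter and both go towards a higher number, and compound 4 combines the two changes. A further rise is therefore expected in this assay, although its size cannot be read from limits. The expected step is a step that the limit leaves unreadable from compound 3 to compound 4. Compound 4 is estimated at 15000 nM, with an expected range of 7000 nM to 40000 nM.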

Compound 4, half-maximal inhibitory concentration: > 10000 nM
Compound 4: only a limit was reported; the forecaster's own chance of this, stated with the estimate: 85%; the middle value lies beyond the limit too.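

The value of compound 4 in this assay is a limit, > 10000 nM. Compound 2 and compound 3 also carry limits, so neither step to compound 4 can be read. The compounds shown leave open whether trifluoromethyl and fluoro together raise the number further than either change alone.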